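Moving the carboxy group on a methyl-bearing ring

The source may report more compounds than this note shows. Statements on the series, on what has been measured and on what is new or still open speak of the compounds shown alone.

- compound 1 `Cc1c(OCCCCOc2ccc(C(=O)O)cc2F)ccc(C(=O)CC2CCCC2)c1O`: 66%
- compound 2 `Cc1ccc(C(=O)O)cc1OCCCCOc1ccc(C(=O)CC2CCCC2)c(O)c1C`: 9%

For the measured compounds named here, in an ADME assay (liver) for metabolic stability, with Liver microsome (Rattus norvegicus) as the target, read by LC-MS, using microsomes and NADPH, with stated times of 5 min and 60 min, tested at 4 uM (on this read-out lower numbers stand for a less stable compound and higher numbers for a more stable compound), compound 2 stands at 9%, the lower of the two numbers so far, while compound 1 gives 66%. The next structure, compound 3 `Cc1cc(OCCCCOc2ccc(C(=O)CC3CCCC3)c(O)c2C)ccc1C(=O)O`, has the same atoms joined differently: 4-carboxy-3-methylphenyl in place of 5-carboxy-2-methylphenyl on an oxygen on a saturated carbon. Going by the values given here, only one measured step bears on this change: a number 57 percentage points lower from compound 1 to compound 2 (beyond the scatter), which is large and beyond the scatter. In that step, the group on the oxygen changed from 4-carboxy-2-fluorophenyl to 5-carboxy-2-methylphenyl. The data cannot show how much of the drop belongs to the methyl and how much to the carboxy numbering. Compound 3 keeps a methyl but returns to the 4-carboxy numbering of compound 1, so a partial recovery seems the likeliest outcome, though a very uncertain one. Among the compounds with values here, the expected change is a number 21 percentage points higher from compound 2 to compound 3 (beyond the scatter), upward and smaller than the one measured step. For compound 3 the estimated value in this assay is 30%, with an expected range of 8% to 65%.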

Compound 3, percent of the compound remaining: 55%
Compound 3: middle estimate off by 25 percentage points, on the low side, within the range that was stated.
By their numbers in this assay, from the lowest: compound 2; then compound 3; then compound 1.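

In this assay, moving from 5-carboxy-2-methylphenyl to 4-carboxy-3-methylphenyl on the oxygen gives a number 46 percentage points higher from compound 2 to compound 3 (beyond the scatter), and since the two compounds have the same atoms, a methyl on this ring does not by itself bring the low number of compound 2; the way the carboxy and methyl groups are arranged on the ring makes a large difference. Against the fluorine-bearing group, 4-carboxy-3-methylphenyl in place of 4-carboxy-2-fluorophenyl gives a number 11 percentage points lower from compound 1 to compound 3 (beyond the scatter), a modest step, so with the 4-carboxy numbering kept, the methyl-bearing ring stays much nearer to compound 1 than compound 2 does. No measurement here gives a reason for either step.

The step between compound 1 and compound 3 changes both the ring substituent and its numbering, so the compounds shown do not separate the effect of swapping fluorine for methyl from that of where the substituent sits. They also leave open how this position would respond to a chlorine or a methoxy group in place of the methyl, or to a tetrazole in place of the carboxylic acid.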